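The source may report more compounds than this note shows. Statements on the series, on what has been measured and on what is new or still open speak of the compounds shown alone.

For the measured compounds named here, in a functional assay on CHO cells with adenosine receptor A1 (Homo sapiens) as the target, read by cAMP accumulation and immunoassay, with a stated time of 6 min, tested at 10 uM (on this read-out lower numbers stand for a stronger effect and higher numbers for a weaker effect at the one concentration tested), compound 3 `Nc1scc(CN2CCN(c3cccc4ccccc34)CC2)c1C(=O)c1ccc(Cl)cc1` gives -21%, the highest of the three numbers so far; compound 2 `Nc1scc(CN2CCN(C3CCCCCC3)CC2)c1C(=O)c1ccc(Cl)cc1` gives -25%, within the scatter of compound 3, while compound 1 `Nc1scc(CN2CCN(c3cccc(Cl)c3Cl)CC2)c1C(=O)c1ccc(Cl)cc1` gives -77%, and the step of a number 56 percentage points higher from compound 1 to compound 3 (beyond the scatter) lies well beyond the scatter. Compound 4 `Nc1scc(CN2CCN(c3ccccc3Cl)CC2)c1C(=O)c1ccc(Cl)cc1` carries the change (2-chlorophenyl in place of naphthalen-1-yl on an amine nitrogen in a ring). The step that bears on it is a number 56 percentage points higher from compound 1 to compound 3 (beyond the scatter) taken in reverse, since 2-chlorophenyl is nearer in kind to 2,3-dichlorophenyl than to naphthalen-1-yl; the step of a number 52 percentage points higher from compound 1 to compound 2 (beyond the scatter) shows a second departure from 2,3-dichlorophenyl of similar size. A large downward step a number 39 percentage points lower from compound 3 to compound 4 (beyond the scatter) is therefore expected in this assay. Compound 4 is estimated at -60%, with a range from -85% to -30%.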

Compound 4, a percentage reported as activity, at one concentration (the size of the read-out at that concentration, not a potency): -18%
Estimate against measurement, compound 4: 42 percentage points below; the whole stated range lies below it.
By their numbers in this assay, from the lowest: compound 1; then compounds 2, 3 and 4 (each within the scatter of the next).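

In this assay, replacing one chloro with hydrogen on the aromatic ring gives a number 59 percentage points higher from compound 1 to compound 4 (beyond the scatter), so a single atom change at this position carries the whole gap. The 2-chlorophenyl group does not keep the number of 2,3-dichlorophenyl and instead stands with the other groups, with a number 3 percentage points higher from compound 3 to compound 4 (within the scatter) and a number 7 percentage points higher from compound 2 to compound 4 (within the scatter). Of the four compounds, only compound 1 stands apart. No measurement available gives a reason for this gap. On these data alone, whether bromo, methyl or methoxy in place of the lost chloro would bring back the number of compound 1 remains open.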